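Fluorophenyl position shift in a weakly inhibiting series

The source may hold more compounds than are shown below. What is called first, only, known or untested is meant among the compounds shown, and "the series" means these compounds.

For the measured compounds named here, compound 2 `Oc1cccc(-c2cc(-c3ccccc3F)cc(-c3ccccc3O)n2)c1` gives 35600 nM in a functional assay on DU-145 cells (Homo sapiens) for inhibition (a lower number here means a stronger inhibitor, a higher number a weaker inhibitor), the only actual number in the set. Compound 1 `Oc1ccccc1-c1cc(-c2cccc(F)c2)cc(-c2ccccc2O)n1` returns only a limit in this assay, > 50000 nM. That limit is the limit of > 50000 nM in this assay, at which 1 of the 2 values shown sits. Compound 3 `Oc1cccc(-c2cc(-c3cccc(F)c3)cc(-c3ccccc3O)n2)c1` differs from compound 2 by 3-fluorophenyl in place of 2-fluorophenyl on an aromatic carbon. Going by the values given here, no measured step covers this change, so the expectation is for a step within the scatter or a mild drift toward weaker inhibition. Compound 3 is estimated at 42000 nM, within 15000 nM to 120000 nM, in this assay. The expected step from compound 2 to compound 3 is a 1.2-fold higher number from compound 2 to compound 3 (0.07 log units; within the scatter).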

Compound 3, half-maximal inhibitory concentration: > 50000 nM
Compound 3: a limit, no number; the forecaster's own chance of this, stated with the estimate: 45%; at least 1.1-fold (0.07 log units) between middle value and limit.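

In this assay, 3-fluorophenyl in place of 2-fluorophenyl on the aromatic carbon opposite the ring nitrogen gives an at least 1.4-fold higher number from compound 2 to compound 3 (0.14 log units; that floor lies within the scatter), so this change has only a floor and no measured size. The step between compound 1 and compound 3 cannot be read, as both values are limits. Most of the set now gives no number: the limit of > 50000 nM in this assay, at which 2 of the 3 values shown sit.

Going by these compounds, the true size of the fluorine shift stays open. Also open, on these data alone, is whether an amine or a carboxylic acid at this position would give a measurable number.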